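This account rests on a few compounds, and the source may have more. Where it says the series, first, only, none or still open, it means among the compounds named here.

Series notes. Compound 1 `CC(C)(C)c1ccc(NC(=O)NCCCCl)cc1` gives 35000 nM in a functional assay on M21 cells (Homo sapiens) for antiproliferative activity, with a stated time of 48 h; on this read-out lower numbers stand for stronger inhibition and higher numbers for weaker inhibition. Compound 2 `CC(C)(C)c1ccc(NC(=O)CCCCl)cc1` reaches only the limit of this assay, > 100000 nM. The step of an at least 2.8-fold higher number from compound 1 to compound 2 (0.45 log units; beyond the scatter) is thus at least modest, compound 2 sitting at the limit of > 100000 nM in this assay, at which 1 of the 3 values shown sits. Compound 3 `C=CC(=O)Nc1ccc(I)cc1` gives 11000 nM, the lowest of the two numbers; its nearest neighbour is compound 1, whose number is higher, beyond the scatter. Compound 4 `C=CC(=O)Nc1ccc(C(C)(C)C)cc1` is not yet measured; it differs from compound 3 by tert-butyl in place of iodo on an aromatic carbon. Going by the values given here, no measured step touches the aromatic substituent: the only measured step concerns the carbonyl side, and compounds 1 and 3 differ in two places, so nothing measured bears directly on this change. For compound 4 a step of a 1.1-fold higher number from compound 3 to compound 4 (0.04 log units; within the scatter) is therefore expected, not beyond the scatter. Compound 4 is estimated at 12000 nM, between 4000 nM and 40000 nM.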

Compound 4, half-maximal inhibitory concentration: 22000 nM
Compound 4: the middle estimate sits 1.8-fold (0.26 log units) below what was measured, within the range that was stated.
By their numbers in this assay, from the lowest: compounds 3, 4 and 1 (each within the scatter of the next, the first and the last beyond it). At a limit, above all of these: compound 2.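

With vinyl held on the carbonyl carbon, tert-butyl in place of iodo on the aromatic carbon leaves the read-out within the scatter: a 2.0-fold higher number from compound 3 to compound 4 (0.30 log units; within the scatter). With tert-butyl held, vinyl on the carbonyl carbon gives an at least 4.5-fold lower number from compound 2 to compound 4 (0.65 log units; beyond the scatter), while the comparison with the urea side gives a 1.6-fold lower number from compound 1 to compound 4 (0.20 log units; within the scatter). The number for compound 2 is a limit: the limit of > 100000 nM in this assay, at which 1 of the 4 values shown sits.

Open, as far as these compounds go, is whether an amine or a carboxylic acid on this aromatic carbon would move the number beyond the scatter. Also open, from the compounds shown here alone, is whether ethyl in place of vinyl would keep it.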